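A Charged Ring Swapped at the End of the Chain

The compounds below may be only part of what the source reports. "The series", "measured", "known", "first", "only" and "open" are said of these compounds alone.

Compound 3 `CN(C)c1ccc2c(=O)c(C(=O)Nc3cc(F)cc(F)c3)cn(-c3ccc(Cl)c(OCCCCCCC[n+]4ccccc4)c3)c2n1` gives 77.9% in an assay on LX2 cells for inhibition of COL1A1 promoter (Homo sapiens), read by a luciferase reporter, with a stated time of 24 h, tested at 50 uM (a lower number here means a weaker effect, a higher number a stronger effect of the compound at the concentration tested), the second highest of the three measured numbers. Compound 2 `CN(C)c1ccc2c(=O)c(C(=O)Nc3cc(F)cc(F)c3)cn(-c3ccc(Cl)c(OCCCCCCC[N+]4(C)CCCCC4)c3)c2n1` gives 90.5%, and compound 1 `CN(C)c1ccc2c(=O)c(C(=O)Nc3cc(F)cc(F)c3)cn(-c3ccc(Cl)c(OCCCCCCC[N+]45CCN(CC4)CC5)c3)c2n1` gives 18.7%. Compound 4 `CC[N+]1(CCCCCCCOc2cc(-n3cc(C(=O)Nc4cc(F)cc(F)c4)c(=O)c4ccc(N(C)C)nc43)ccc2Cl)CCCCC1` differs from compound 3 by a group of 8 heavy atoms (7 carbon, 1 nitrogen; one six-membered non-aromatic ring with 1 hetero atom) in place of a group of 6 heavy atoms (5 carbon, 1 nitrogen; one six-membered aromatic ring with 1 hetero atom), on a saturated chain carbon, seven bonds along the chain from an oxygen on an aromatic ring. The step that bears most on this is a number 12.6 percentage points lower from compound 2 to compound 3 (beyond the scatter), a modest loss when a six-membered non-aromatic ring gave way to a six-membered aromatic ring at the same place on the chain. Compound 4 reverses that kind of swap, and the large steps of a number 71.8 percentage points higher from compound 1 to compound 2 (beyond the scatter) and a number 59.2 percentage points higher from compound 1 to compound 3 (beyond the scatter) show that changes of this charged ring can move the number far. A modest rise is therefore expected, a number 10.1 percentage points higher from compound 3 to compound 4 (beyond the scatter). Compound 4 is estimated at 88%, between 74% and 97%.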

Compound 4, a percentage reported as inhibition, at one concentration (the size of the read-out at that concentration, not a potency): "not active" (no number reported)
Compound 4: no number reported; the estimate stays without a comparison.
By their numbers in this assay, from the lowest: compound 1; then compound 3; then compound 2.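

For the compounds shown here, compound 4 is reported as "not active", without a number, so no step from compound 3 to compound 4 can be read in this assay. Nothing available here bears on this result. Going by these compounds, how far compound 4 actually lies from compound 3 remains open.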